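A few compounds are considered here, and "the series" means these few. Any claim that something is new, unique, unknown or untested is made for them only; others in the source may bear on it.

Working notes on the series. Going by the values given here, in an ADME assay on HEK293 cells (Homo sapiens) for cytotoxicity (on this read-out lower numbers stand for stronger inhibition and higher numbers for weaker inhibition), compound 1 `CCCCCCCCCCCCCCNC(=O)[C@H](CO)/N=C/c1cccc(C)c1` gives 51100 nM and compound 2 `CCCCCCCCCCCCCCNC(=O)[C@H](CO)/N=C/c1ccccc1[N+](=O)[O-]` gives 82600 nM so compound 2 stands within the scatter of compound 1, its only measured neighbour. Compound 3 `CCCCCCCCCCCCCCNC(=O)[C@H](CO)/N=C/c1ccccc1OC` carries methoxy in place of nitro on an aromatic carbon, ortho to a large group, relative to compound 2 (methoxy in place of nitro on an aromatic carbon). Among the compounds with values here, the one measured step that bears on this is a 1.6-fold higher number from compound 1 to compound 2 (0.21 log units; within the scatter) and it likewise exchanges the substituent on the phenyl group. Within the data shown here, with only that step to go on, no step beyond the scatter is expected in this assay and no direction can be firmly assigned. The expected step is a 1.3-fold lower number from compound 2 to compound 3 (0.10 log units; within the scatter) and it rests on this single comparison. Compound 3 is expected at 65000 nM (estimated range 33000 nM to 125000 nM).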

Compound 3, half-maximal inhibitory concentration: 79200 nM
Beside the measured number, compound 3's estimate is 1.2-fold (0.09 log units) below it, and the stated range covers the measured number.
By their numbers in this assay, from the lowest: compounds 1, 3 and 2 (each within the scatter of the next).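

In this assay, methoxy in place of nitro on this aromatic carbon, ortho to a large group, gives a 1.0-fold lower number from compound 2 to compound 3 (0.02 log units; within the scatter), so this exchange, the first shown at this position with the substitution pattern held, does not separate the two groups. Comparing the 2-methoxyphenyl and 3-methylphenyl groups gives a 1.5-fold higher number from compound 1 to compound 3 (0.19 log units; within the scatter), which places all three phenyl variants on the shared core within the scatter of one another. No evidence is available that accounts for these readings.

The compounds shown leave open whether an amine or a carboxylic acid on this aromatic carbon would give a step beyond the scatter. They also leave open whether a change away from the phenyl group, such as a shorter chain, would shift the number in this assay.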